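A few compounds are considered here, and "the series" means these few. Any claim that something is new, unique, unknown or untested is made for them only; others in the source may bear on it.

Compound 1 `Cc1ccc(-n2cc(CNC(=O)c3cccc4c3cnn4C(C)C)nn2)c(C)c1` gives in a functional assay on MGC-803 cells (Homo sapiens) for inhibition, read by MTT assay, with a stated time of 72 h (on this read-out higher numbers stand for weaker inhibition and lower numbers for stronger inhibition), a value of > 40000 nM, which is a limit of the assay and not a number.
Compound 2 `CC(C)n1ncc2c(C(=O)NCc3cn(-c4ccc(I)cc4)nn3)cccc21` gives in this assay a value of > 40000 nM, again a limit of the assay.
Compound 3 `CC(C)n1ncc2c(C(=O)NCc3cn(-c4ccccc4F)nn3)cccc21` gives in this assay a value of > 40000 nM, once more a limit of the assay.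

Compound 3 therefore stands nowhere in particular on the numbers shown: all three measured compounds sit at the same point, namely (the limit of > 40000 nM in this assay, at which 3 of the 3 values shown sit). The three changes among them swap one group on the aromatic nitrogen of the shared core, yet their sizes cannot be read, since a step that the two limits leave unreadable from compound 1 to compound 2, a step that the two limits leave unreadable from compound 1 to compound 3 and a step that the two limits leave unreadable from compound 2 to compound 3 each run between two limits.

Compound 4 `COc1ccc(Cn2cc(CNC(=O)c3cccc4c3cnn4C(C)C)nn2)cc1` differs from compound 3 in that same place: 4-methoxybenzyl in place of 2-fluorophenyl on an aromatic nitrogen. Among the compounds with values here, none of the measured steps puts a benzyl group on that nitrogen, so no measured step bears directly on this change, and the steps that do touch the position give no readable size. With nothing pointing to a gain in potency, compound 4 is expected to remain at or beyond the limit, so the estimated step that the limit leaves unreadable from compound 3 to compound 4 is expected to be none beyond the scatter. Compound 4 is estimated at 50000 nM, within a range from 10000 nM to 200000 nM, and most likely reported only as a limit.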

Compound 4, half-maximal inhibitory concentration: > 40000 nM
Compound 4: no number, only a limit; the forecaster's own chance of this, stated with the estimate: 80%; the middle value is on the limit's open side.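

In this assay compound 4 gives > 40000 nM, a limit of the assay and not a number. No step between compound 1, compound 2, compound 3 and compound 4 can be read, since all four stand at one point: the limit of > 40000 nM in this assay, at which 4 of the 4 values shown sit.

The compounds shown leave open whether any group on that aromatic nitrogen gives a measurable inhibition, and how these four groups would rank.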